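Cyano in Place of Acetyl: What Compound 3 Might Give

The source may hold more compounds than are shown below. What is called first, only, known or untested is meant among the compounds shown, and "the series" means these compounds.

Compound 1, `CCOC(=O)C(=Cc1c(-c2ccccc2)[nH]c2ccccc12)C(=O)OCC`, gives 18500 nM in a functional assay on OVCAR-5 cells (Homo sapiens) for inhibition, read by sulforhodamine B assay, with a stated time of 48 h; on this read-out higher numbers stand for weaker inhibition of growth and lower numbers for stronger inhibition of growth.
Compound 2, `CC(=O)/C(=C\c1c(-c2ccccc2)[nH]c2ccccc12)S(=O)(=O)c1ccccc1`, gives 2000 nM in this assay.

Among the measured compounds shown here, of the two compounds measured so far, compound 2 has the lowest number in this assay. Its nearest neighbour is compound 1, whose number is higher by a margin that lies beyond the usual scatter of this kind of measurement, so compound 2 is the stronger growth inhibitor of the pair. For the measured compounds named here, no pair of the measured compounds differs in just one place, so no single step has been measured.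

Compound 3, `N#C/C(=C\c1c(-c2ccccc2)[nH]c2ccccc12)S(=O)(=O)c1ccccc1`, has not yet been measured. It differs from compound 2 in one place: cyano in place of acetyl on a double-bonded chain carbon bound to a double-bonded chain carbon and a sulfonyl sulfur. Going by the values given here, with no measured step of this kind to lean on, the expectation rests on the value of compound 2 alone. The step of a 1.3-fold lower number from compound 2 to compound 3 (0.12 log units; within the scatter) is expected to be small, at most modestly toward stronger inhibition, and may well lie within the scatter. Compound 3 is therefore estimated at 1500 nM, with a likely range from 400 nM to 6000 nM.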

Compound 3, concentration for 50% growth inhibition: 13900 nM
Compound 3: middle estimate off by 9.3-fold (0.97 log units), on the low side, outside the stated range (above it).
By their numbers in this assay, from the lowest: compound 2; then compounds 3 and 1 (each within the scatter of the next).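

In this assay, among the compounds shown here, cyano in place of acetyl on a double-bonded chain carbon bound to a double-bonded chain carbon and a sulfonyl sulfur gives a 7.0-fold higher number from compound 2 to compound 3 (0.84 log units; beyond the scatter), the first single change in this set with a measured effect. For the compounds shown here, it shows that this position is sensitive to the group it carries, which the earlier compounds could not show, since they differ from each other in more than one place. Of the two groups seen here, acetyl goes with the stronger inhibition of growth, even though the counts of hydrogen-bond donors and acceptors under this change stay the same, so those counts alone do not follow the step.

From the compounds shown here alone, whether an amide, a carboxylic acid or a longer ketone chain at this place would stay close to compound 2 or fall away toward compound 3 remains open. Also open, going by these compounds, is whether the same step would appear with a group other than the phenyl sulfonyl on the chain. Nothing measured here accounts for the size of this step, and its reason stays unknown.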